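A few compounds are considered here, and "the series" means these few. Any claim that something is new, unique, unknown or untested is made for them only; others in the source may bear on it.

In an assay on CHO-K1 cells for displacement of a labelled ligand from melanin-concentrating hormone receptor 1 (Homo sapiens), read by scintillation proximity assay, with a stated time of 2 h (on this read-out lower numbers stand for stronger inhibition and higher numbers for weaker inhibition), three compounds built on a shared core have been measured. Compound 1 `Cc1nc(N(C)C2CCCC2)nc2ccc(NC(=O)/C=C/c3ccc(Cl)cc3)cc12` gives 399 nM, compound 2 `C/C(=C\C(=O)Nc1ccc2nc(N3CCC(O)CC3)nc(C)c2c1)c1ccc(Cl)cc1` gives 670 nM, and compound 3 `COCC(=O)NC1CCN(c2nc(C)c3cc(NC(=O)/C=C/c4ccc(OC(F)(F)F)cc4)ccc3n2)CC1` gives 32 nM. Compound 3 thus stands with the lowest number of the three; the gap to compound 1, its nearest neighbour, and the wider gap to compound 2 both lie beyond the usual scatter, so compound 3 is the most potent of the measured set in this assay.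

Compound 4 `Cc1nc(N2CCC(N3CCCC3=O)CC2)nc2ccc(NC(=O)/C=C/c3ccc(OC(F)(F)F)cc3)cc12` is the next compound, not yet measured. It differs from compound 3 in one place: 2-oxopyrrolidin-1-yl in place of ((methoxymethyl)carbonyl)amino on a saturated ring carbon. Among the measured compounds shown here, no pair of measured compounds shows this particular exchange, so the expectation rests on the description of the change alone. Leaving and entering groups match in heavy-atom count, and the rest of the molecule, including the trifluoromethoxy-bearing side, is unchanged. The step from compound 3 to compound 4 is therefore expected to be small, a 1.3-fold higher number from compound 3 to compound 4 (0.10 log units; within the scatter), most likely within the scatter, with no clear direction favoured. Compound 4 is expected to give 40 nM in this assay, with a plausible range from 12 nM to 130 nM.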

Compound 4, half-maximal inhibitory concentration: 11 nM
For compound 4 the middle estimate is 3.6-fold (0.56 log units) above the measured one; the measured number lies below the stated range.
By their numbers in this assay, from the lowest: compound 4; then compound 3; then compounds 1 and 2 (each within the scatter of the next).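

In this assay, replacing the open-chain ((methoxymethyl)carbonyl)amino group with the cyclic 2-oxopyrrolidin-1-yl group on the saturated ring carbon gives a 2.9-fold lower number from compound 3 to compound 4 (0.46 log units; beyond the scatter), a step beyond the usual scatter. This shows that the read-out responds to the form of the group at this carbon, even though the leaving and entering groups have the same heavy-atom count and the rest of the molecule is unchanged. No measurement shown explains why the number falls.

The single step changes several things at once: the entering group adds a five-membered ring, has no hydrogen-bond donor and has one hydrogen-bond acceptor fewer, so the compounds shown cannot separate the contribution of each. Going by these compounds, an open-chain amide with a methyl group on its nitrogen, the six-membered 2-oxopiperidin-1-yl group or a simple amine at this carbon would each test a different part of the change, and whether the step holds with another group on the far side of the molecule also remains open.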